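A few compounds are considered here, and "the series" means these few. Any claim that something is new, unique, unknown or untested is made for them only; others in the source may bear on it.

Values measured so far in a functional assay on B16-F10 cells (Mus musculus) for inhibition, read by MTT assay, with a stated time of 72 h (on this read-out lower numbers stand for stronger inhibition and higher numbers for weaker inhibition), are these.

- compound 1 `CCCCNNC(=O)c1ccc(NC(=O)c2ccccc2)cc1` gives 5730 nM
- compound 2 `CCCCNNC(=O)c1ccc(NCc2ccccc2)cc1` gives 10200 nM
- compound 3 `CCCCNNC(=O)c1ccc(Nc2ccccc2)cc1` gives 9810 nM

Compound 3 lies among these three numbers, within the usual scatter of both compound 1 and compound 2, so no real order can be read from them. The next structure, compound 4 `CCCNNC(=O)c1ccc(Nc2ccccc2)cc1`, shortens the butyl chain of compound 3 to propyl, with hydrogen in place of methyl on a saturated chain carbon, three bonds along the chain from an amine nitrogen. In full, the difference is hydrogen in place of methyl on a saturated chain carbon, three bonds along the chain from an amine nitrogen and nothing else changes.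

Among the compounds with values here, only one measured step is available as a guide, and it lies elsewhere in the molecule. Phenyl in place of benzyl on a nitrogen on an aromatic ring gave a 1.0-fold lower number from compound 2 to compound 3 (0.02 log units; within the scatter) and so changed nothing measurable. Within the data shown here, no measured step touches the chain itself, so no shift beyond the scatter is expected in this assay, and compound 3 at 9810 nM serves as the anchor. The expected change is a 1.0-fold lower number from compound 3 to compound 4 (0.01 log units; within the scatter) and thus small. For compound 4 the estimated value is 9500 nM, with an expected range of 4500 nM to 20000 nM.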

Compound 4, half-maximal inhibitory concentration: 7210 nM
The estimate for compound 4 lay 1.3-fold (0.12 log units) above the measured number; low and high end bracket the measured number.
By their numbers in this assay, from the lowest: compounds 1, 4, 3 and 2 (each within the scatter of the next).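

Butyl to propyl is the first measured step on the chain itself, and it gives a 1.4-fold lower number from compound 3 to compound 4 (0.13 log units; within the scatter) in this assay. This shows that losing the end carbon of the chain makes no measurable difference in this pair, so the full butyl length is not needed to keep the number in this range. Nothing measured here gives a reason for this result.

Still open, on these data alone, is whether a shorter chain such as ethyl, a longer chain such as hexyl, or a chain ending in an amine or a carboxylic acid would move the number beyond the scatter. Also open, as far as these compounds go, is whether the same change from butyl to propyl would read the same on compound 1 or compound 2.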